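Benzothiazole amide: fluoro to dimethyl, effect unknown

The compounds below may be only part of what the source reports. "The series", "measured", "known", "first", "only" and "open" are said of these compounds alone.

Measured compounds:
compound 1, `COc1ccc(-c2cc(C(=O)Nc3nc4ccc(F)cc4s3)nc3cc(-c4ccccc4)nn23)cc1`: 35500 nM
compound 2, `COc1cc(-c2cc(C(=O)Nc3nc4ccc(F)cc4s3)nc3cc(-c4ccccc4)nn23)cc(OC)c1OC`: 27500 nM

In a functional assay on MCF7 cells (Homo sapiens) for cytotoxicity, read by MTT assay, with a stated time of 48 h (on this read-out lower numbers stand for stronger inhibition and higher numbers for weaker inhibition), compound 1 gives 35500 nM, and compound 2 gives 27500 nM. These two numbers lie within the scatter of each other, so compound 1 does not stand apart from compound 2 on this read-out. Among the compounds with values here, the one measured step, a 1.3-fold lower number from compound 1 to compound 2 (0.11 log units; within the scatter), changes the aryl group on an aromatic carbon of the shared core and leaves the benzothiazole amide untouched.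

Compound 3, `COc1ccc(-c2cc(C(=O)Nc3nc4cc(C)c(C)cc4s3)nc3cc(-c4ccccc4)nn23)cc1`, differs from compound 1 at the other end: 5,6-dimethyl-1,3-benzothiazol-2-yl in place of 6-fluoro-1,3-benzothiazol-2-yl on an amide-type nitrogen. Within the data shown here, no measured step touches this position, so the step from compound 1 to compound 2 gives no guide to its size or direction; the only reference is compound 1 itself.

Compound 3 is therefore expected to stay near compound 1, with a step of a 1.0-fold lower number from compound 1 to compound 3 (0.01 log units; within the scatter), with the range kept wide. The estimate for compound 3 is 35000 nM, between 10000 nM and 100000 nM.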

Compound 3, half-maximal inhibitory concentration: 19700 nM
For compound 3 the middle estimate is 1.8-fold (0.25 log units) above the measured one; the measured number falls inside the stated range.
By their numbers in this assay, from the lowest: compounds 3, 2 and 1 (each within the scatter of the next).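

Within the data shown here, putting 5,6-dimethyl-1,3-benzothiazol-2-yl in place of 6-fluoro-1,3-benzothiazol-2-yl on the amide-type nitrogen gives the first reading at this position: in this assay the exchange is a 1.8-fold lower number from compound 1 to compound 3 (0.26 log units; within the scatter). This end of the molecule can therefore carry either group without a step beyond the scatter, so compound 1 and compound 3 do not stand apart on this read-out. Nothing measured here bears on why this exchange reads as it does.

As far as these compounds go, it remains open whether another group on the benzothiazole, such as an amine, a carboxylic acid or a methoxy group, would give a step beyond the scatter. Also open, from the compounds shown here alone, is whether the same exchange would read alike on the 3,4,5-trimethoxyphenyl compound, compound 2.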